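A few compounds are considered here, and "the series" means these few. Any claim that something is new, unique, unknown or untested is made for them only; others in the source may bear on it.

Measured compounds:
- compound 1 `CCCCC[Se]c1nc([Se]CCCCC)c2cccnc2n1`: > 100000 nM
- compound 2 `Nc1nc([SeH])nc2ncccc12`: 30900 nM
- compound 3 `[SeH]c1nc([SeH])c2cccnc2n1`: "not determined" (no result reported)

Among the compounds with values here, in a functional assay on CCRF-CEM cells (Homo sapiens) for cytotoxicity, read by MTT assay, with a stated time of 72 h (a higher number here means a weaker inhibitor of growth, a lower number a stronger inhibitor of growth), compound 2 gives 30900 nM, the only plain number in the set. For compound 1 the assay reports only a limit, > 100000 nM, so no number is known for it (the limit of > 100000 nM in this assay, at which 1 of the 3 values shown sits). Compound 3 carries no result in this assay at all, so compound 2 stands alone among the measured compounds as a point of reference.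

Compound 4 `CCCCC[Se]c1nc(N)c2cccnc2n1` differs from compound 2 in one place: pentyl in place of hydrogen on a selenium. Within the data shown here, no pair of measured compounds differs in exactly this way, so no measured step is available to lean on. What can be said is that compound 1, which carries pentyl on both of its selenium atoms, sits at the limit of this assay, whereas compound 2, with hydrogen on selenium, returns a number. On that basis the expected step from compound 2 to compound 4 in this assay is a 1.9-fold higher number from compound 2 to compound 4 (0.29 log units; within the scatter), that is towards weaker growth inhibition, with a real chance that only a limit is returned. Compound 4 is therefore estimated at 60000 nM in this assay, within 15000 nM to 200000 nM.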

Compound 4, concentration for 50% growth inhibition: 12900 nM
Compound 4: the middle estimate sits 4.7-fold (0.67 log units) above what was measured; the whole stated range lies above it.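

In this assay, pentyl in place of hydrogen on a selenium is a step that can be read, and it runs towards stronger growth inhibition: a 2.4-fold lower number from compound 2 to compound 4 (0.38 log units; beyond the scatter). Compound 1 carries pentyl on both selenium atoms and gives a limit, not a number: the limit of > 100000 nM in this assay, at which 1 of the 4 values shown sits. Its contrast with compound 4 shows that pentyl on one selenium does not by itself go with that limit, since one nitrogen atom in place of the group of 6 heavy atoms on an aromatic carbon gives an at least 7.7-fold lower number from compound 1 to compound 4 (0.88 log units; beyond the scatter).

From the compounds shown here alone, whether methyl, a longer chain such as octyl, or benzyl on the selenium would carry this step further remains open. Going by these compounds, a single step on a single chain supports no trend with chain length, and the effect of a methylamine in place of the free amine also remains unknown.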